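The source may hold more compounds than are shown below. What is called first, only, known or untested is meant among the compounds shown, and "the series" means these compounds.

Working notes on the series. The core shared by all entries is a fused two-ring acetal; compound 1 `C=CC[C@@H]1O[C@@H]2CO[C@@H](c3ccccc3)O[C@H]2[C@H](OC)[C@H]1OC` carries an allyl group, compound 2 `CO[C@@H]1[C@@H](OC)[C@H](Cc2ccccc2)O[C@@H]2CO[C@@H](c3ccccc3)O[C@@H]12` a benzyl group, and compound 3 `CO[C@@H]1[C@@H](OC)[C@H](c2ccccc2)O[C@@H]2CO[C@@H](c3cccs3)O[C@@H]12` a phenyl group on the same saturated ring carbon, with the acetal carbon bearing phenyl in compounds 1 and 2 and thiophen-2-yl in compound 3. In a functional assay on HEL cells (Homo sapiens) for cytotoxicity (on this read-out lower numbers stand for higher toxicity in this test and higher numbers for lower toxicity in this test), compound 2 gives 20 ug/mL. For compound 1 the entry in this assay reads "not determined" (no result reported), so no result was reported. Compound 3 likewise has no single number in this assay, its entry reading "not determined" (no result reported), so it stands without a measured value, as does one further entry in the set; nothing measured describes the series beyond compound 2.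

The next entry is compound 4 `CO[C@@H]1[C@@H](OC)[C@H](c2ccccc2)O[C@@H]2CO[C@@H](c3ccc(C(F)(F)F)cc3)O[C@@H]12`. From compound 3 to compound 4 the change is 4-(trifluoromethyl)phenyl in place of thiophen-2-yl on a saturated ring carbon. Among the compounds with values here, no pair of measured compounds shows what a change of this kind does to the readout, and the only number in the set belongs to a compound of a different pattern. In this assay no step beyond the scatter is expected in either direction. Compound 4 is estimated at 20 ug/mL in this assay, with the expected range running from 7 ug/mL to 60 ug/mL.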

Compound 4, minimum cytotoxic concentration: >= 16 ug/mL
Compound 4 was reported as a limit; the forecaster's own chance of this, stated with the estimate: 40%; the middle value is on the limit's open side.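

No step can be read from compound 3 to compound 4 in this assay. The entry for compound 4 is a limit and not a number: the limit of >= 16 ug/mL in this assay, at which 1 of the 4 values shown sits.

The compounds shown leave open how thiophen-2-yl and 4-(trifluoromethyl)phenyl on the saturated ring carbon between the two ring oxygen atoms compare in this assay.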